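The source may report more compounds than this note shows. Statements on the series, on what has been measured and on what is new or still open speak of the compounds shown alone.

Series notes. Compound 1 `N#Cc1c(Nc2ccc(Cl)cc2)nc(SCc2cn(Cc3ccccc3Cl)nn2)nc1-c1ccccc1` gives 1420 nM in a functional assay on ECa-109 cells (Homo sapiens) for inhibition, read by MTT assay, with a stated time of 72 h; a lower number here means a stronger inhibitor, a higher number a weaker inhibitor. Compound 2 `N#Cc1c(Nc2ccc(F)cc2)nc(SCc2cn(Cc3ccccc3Cl)nn2)nc1-c1ccccc1` gives 25800 nM. The change (fluoro in place of chloro on an aromatic carbon), on the (4-chlorophenyl)amino group, made the step of an 18-fold higher number from compound 1 to compound 2 (1.26 log units; beyond the scatter). Compound 3 `Cc1ccc(Nc2nc(SCc3cn(Cc4ccc(Cl)cc4)nn3)nc(-c3ccccc3)c2C#N)cc1` reaches only the limit > 64000 nM in this assay; it is a limit, not a number, so the change of core from compound 1 to compound 3 is not broken down here. Compound 4 `Cc1ccc(Nc2nc(SCc3cn(Cc4ccc(F)cc4)nn3)nc(-c3ccccc3)c2C#N)cc1` carries the same change, (fluoro in place of chloro on an aromatic carbon), now on the 4-chlorobenzyl group. From compound 1 to compound 2 the same change was followed by a large loss; compound 3 already sits at the limit of > 64000 nM in this assay, at which 1 of the 3 values shown sits. Compound 4 is therefore expected to remain at or beyond that limit, with the expected step that the limit leaves unreadable from compound 3 to compound 4, and the estimate for compound 4 is 120000 nM, with the range 64000 nM to 400000 nM.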

Compound 4, half-maximal inhibitory concentration: 42700 nM
The estimate for compound 4 lay 2.8-fold (0.45 log units) above the measured number; the whole stated range lies above it.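

In this assay, the change on the core of compound 3 gave an at least 1.4-fold lower number from compound 3 to compound 4 (0.17 log units; that floor lies within the scatter), so the large loss seen on the core of compound 1 did not repeat. Fluoro in place of chloro therefore does not carry over as one fixed step in this series: the same change on two cores in this assay, an 18-fold higher number (1.26 log units; beyond the scatter) from compound 1 to compound 2 and an at least 1.4-fold lower number (0.17 log units; that floor lies within the scatter) from compound 3 to compound 4, at least 27-fold (1.43 log units) apart, beyond the scatter of two such steps

On these data alone, compound 3 stands at > 64000 nM, which is a limit and not a number, so the full size of its step stays unknown, and the two pairs do not show whether the site of the change (the 4-chlorophenyl group or the 4-chlorobenzyl group) or the rest of the structure sets the gap.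

Still open, as far as these compounds go, is whether bromo or methoxy in place of the chloro would follow either step. Also open, from the compounds shown here alone, is how the same change reads on the other group of each pair.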